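The compounds below may be only part of what the source reports. "The series", "measured", "known", "first", "only" and "open" are said of these compounds alone.

Among the compounds with values here, in a functional assay on HCT-116 cells (Homo sapiens) for antiproliferative activity, read by MTT assay, with a stated time of 72 h (a higher number here means a weaker inhibitor, a lower number a stronger inhibitor), compound 1 `NC1=NC2(CCOCC2)N(OCCCOc2ccccc2)C(N)=N1` gives 6010 nM, the highest number of the three compounds measured so far, which makes it the weakest inhibitor among them. Compound 2 `Cc1cc(C)cc(OCCCON2C(N)=NC(N)=NC23CCOCC3)c1` gives 190 nM, and compound 3 `NC1=NC2(CCOCC2)N(OCCCOc2ccc(Cl)cc2Cl)C(N)=N1` gives 880 nM. These three share a core and differ only in the group on an oxygen on a saturated carbon.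

Compound 4 `NC1=NC2(CCOCC2)N(OCCCOc2ccc(Cl)c(Cl)c2)C(N)=N1` has not yet been measured. It changes that same place in compound 1: 3,4-dichlorophenyl in place of phenyl on an oxygen on a saturated carbon. Two measured changes from phenyl bear on this: the large 32-fold lower number from compound 1 to compound 2 (1.50 log units; beyond the scatter) and the modest 6.8-fold lower number from compound 1 to compound 3 (0.83 log units; beyond the scatter). Both lower the number, but the gap a 4.6-fold higher number from compound 2 to compound 3 (0.67 log units; beyond the scatter) shows that the choice of replacing group matters. Compound 3, also a dichlorophenyl compound, is the closer guide, so a lower number of modest size is expected rather than a large drop. The expected change is a 10-fold lower number from compound 1 to compound 4 (1.00 log units; beyond the scatter). For compound 4 the estimated value is 600 nM, with an expected range from 200 nM to 1800 nM.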

Compound 4, half-maximal inhibitory concentration: 90 nM
Estimate against measurement, compound 4: 6.7-fold (0.82 log units) above; the whole stated range lies above it.
By their numbers in this assay, from the lowest: compound 4; then compound 2; then compound 3; then compound 1.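

In this assay, where the chlorines sit matters as well as whether they are there: 2,4-dichlorophenyl and 3,4-dichlorophenyl have the same atoms, yet there is a 9.8-fold lower number from compound 3 to compound 4 (0.99 log units; beyond the scatter). The replacement of phenyl now gives a 67-fold lower number from compound 1 to compound 4 (1.82 log units; beyond the scatter), so this position can take a far larger gain than compound 3 alone suggested. The 3,4-dichlorophenyl group also edges past 3,5-dimethylphenyl, with a 2.1-fold lower number from compound 2 to compound 4 (0.32 log units; beyond the scatter), a small step but one that lies beyond the scatter, which makes compound 4 the strongest inhibitor of the four.

Nothing available here explains why the two dichlorophenyl groups differ so much. Also open, from the compounds shown here alone, is whether a pyridine ring in place of the phenyl, an amine on that ring, or a longer chain would keep the number this low.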